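A few compounds are considered here, and "the series" means these few. Any claim that something is new, unique, unknown or untested is made for them only; others in the source may bear on it.

In a physicochemical assay, with a stated time of 30 min (a lower number here means a stronger inhibitor, a higher number a weaker inhibitor), compound 1 `COc1cc2c(cc1OC)C(=O)C(C(=O)Nc1ccc(Br)cc1)C2` gives 72.1 ug/mL and compound 2 `CCOc1cccc(NC(=O)C2Cc3cc(OC)c(OC)cc3C2=O)c1` gives 44.9 ug/mL. These two numbers lie within the usual scatter of each other, so compound 2 stands level with compound 1 and no ranking can be drawn. Among the compounds with values here, no pair of measured compounds differs in a single place, so no measured step is available as a guide.

Compound 3 `COc1cc2c(cc1OC)C(=O)C(C(=O)Nc1cccc(Cl)c1)C2` keeps the shared core of compound 2 and changes one group: chloro in place of ethoxy on an aromatic carbon, meta to a large group (chloro in place of ethoxy on an aromatic carbon). The only hint, and a weak one, is that compound 1 also carries a halogen and gives 72.1 ug/mL. The expected change, a 1.2-fold higher number from compound 2 to compound 3 (0.09 log units; within the scatter), is a slightly higher number that is estimated to stay within the scatter. For compound 3 the estimated value is 55 ug/mL, with an expected range from 25 ug/mL to 110 ug/mL.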

Compound 3, half-maximal inhibitory concentration: 76.3 ug/mL
Beside the measured number, compound 3's estimate is 1.4-fold (0.14 log units) below it; measured number inside the range.
By their numbers in this assay, from the lowest: compounds 2, 1 and 3 (each within the scatter of the next).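

In this assay, chloro in place of ethoxy on an aromatic carbon, meta to a large group, gives a 1.7-fold higher number from compound 2 to compound 3 (0.23 log units; within the scatter), so a group of 3 heavy atoms with 1 hydrogen-bond acceptor can give way to a single chlorine atom with no readable difference. The change of 4-bromophenyl to 3-chlorophenyl on the amide-type nitrogen gives a 1.1-fold higher number from compound 1 to compound 3 (0.02 log units; within the scatter), so this swap of aryl group also leaves the two compounds level. Nothing measured here explains why these numbers stay level.

No step shown so far lies beyond the scatter, so what would truly shift the number at this position remains unknown. An amine, a carboxylic acid or a longer chain such as butoxy at this position could still give a different answer.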